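This account rests on a few compounds, and the source may have more. Where it says the series, first, only, none or still open, it means among the compounds named here.

Measured so far:
compound 1, `CC(C)c1noc(N2CCN(C(=O)[C@@H]3CCCN(S(=O)(=O)c4ccc(S(=O)(=O)NC5CC5)cc4)C3)CC2)n1`: 6700 nM
compound 2, `CCN(CC)C(=O)c1ccc(S(=O)(=O)N2CCC[C@@H](C(=O)N3CCN(c4nc(C(C)C)no4)CC3)C2)cc1`: 1400 nM

Both values come from a functional assay on BXPC-3 cells (Homo sapiens) for inhibition, read by MTT assay, with a stated time of 7 days; a higher number here means a weaker inhibitor, a lower number a stronger inhibitor. Within the data shown here, of the two numbers, compound 2 has the lower one and is thus the stronger inhibitor; the only measured step, from compound 1 to compound 2, is a 4.8-fold lower number from compound 1 to compound 2 (0.68 log units; beyond the scatter).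

Compound 3, `CC(C)c1noc(N2CCN(C(=O)[C@@H]3CCCN(S(=O)(=O)c4ccc(S(=O)(=O)NC(C)(C)C)cc4)C3)CC2)n1`, has not yet been measured. It differs from compound 2 in one place: (tert-butyl)sulfamoyl in place of diethylcarbamoyl on an aromatic carbon. Among the measured compounds shown here, this change largely undoes the one measured step: the diethylcarbamoyl that distinguishes compound 2 from compound 1 leaves, and a sulfamoyl group returns, now bearing a tert-butyl instead of the cyclopropyl of compound 1. The step of a 4.8-fold lower number from compound 1 to compound 2 (0.68 log units; beyond the scatter) is therefore the one that bears on this change, and it was modest but beyond the scatter. Nothing measured shows how a tert-butyl and a cyclopropyl on the sulfamoyl nitrogen compare, so that part is an open question.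

The expected outcome is that compound 3 moves back toward compound 1, an estimated step of a 3.6-fold higher number from compound 2 to compound 3 (0.55 log units; beyond the scatter) in this assay. Compound 3 is accordingly estimated at 5000 nM, with an expected range from 2000 nM to 15000 nM.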

Compound 3, half-maximal inhibitory concentration: 2600 nM
The estimate for compound 3 lay 1.9-fold (0.28 log units) above the measured number, within the range that was stated.
By their numbers in this assay, from the lowest: compounds 2 and 3 (each within the scatter of the next); then compound 1.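

In this assay, (tert-butyl)sulfamoyl in place of diethylcarbamoyl on the aromatic carbon gives a 1.9-fold higher number from compound 2 to compound 3 (0.27 log units; within the scatter) and so leaves compound 2 and compound 3 within the scatter of each other, which shows that a sulfamoyl group at this position does not by itself return the number to that of compound 1. The group on the sulfonamide nitrogen also matters, since tert-butyl in place of cyclopropyl gives a 2.6-fold lower number from compound 1 to compound 3 (0.41 log units; beyond the scatter) in the same assay, a modest change but one beyond the scatter, so the gap between compound 1 and compound 2 cannot be credited to the diethylcarbamoyl alone. No measured evidence is available to explain why these two groups on the nitrogen differ.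

On these data alone, with only cyclopropyl and tert-butyl on that nitrogen, it remains open whether a methyl, a longer chain such as n-butyl, or the plain sulfonamide with no carbon group on its nitrogen would sit nearer compound 1 or compound 3. As far as these compounds go, it is also open how a carboxylic acid or a simple amine would behave at the same aromatic carbon.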